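A few compounds are considered here, and "the series" means these few. Any claim that something is new, unique, unknown or untested is made for them only; others in the source may bear on it.

Working notes on the series, read in a functional assay on T47D cells (Homo sapiens) for cytotoxicity, read by MTT assay, with a stated time of 2 days; on this read-out lower numbers stand for stronger inhibition and higher numbers for weaker inhibition.

Compound 3, `Cc1ccc2nc(-c3ccccc3F)[nH]c(=O)c2c1`, gives in this assay a value that is a limit of the assay and not a number, > 50000 nM. Compound 1, `Cc1ccc2nc(-c3ccccc3N(C)C)[nH]c(=O)c2c1`, gives 26700 nM in this assay. The change between the two is dimethylamino in place of fluoro on an aromatic carbon, and it made the step of an at least 1.8-fold lower number from compound 3 to compound 1 (0.27 log units; that floor lies within the scatter); that two of the three values shown sit at the limit of > 50000 nM in this assay, at which 2 of the 3 values shown sit, keeps the size of this step uncertain.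

Compound 2, `Cc1ccc2c(=O)[nH]c(-c3ccccc3F)nc2c1`, likewise gives only a limit of the assay and not a number in this assay, > 50000 nM. The difference between the core of compound 2 and the core of compound 3 is not broken down here.

Compound 4, `Cc1ccc2c(=O)[nH]c(-c3ccccc3N(C)C)nc2c1`, is not yet measured in this assay. It stands to compound 2 as compound 1 stands to compound 3: the change is dimethylamino in place of fluoro on an aromatic carbon, the same change, at the same place. The step is expected to be an at least 1.6-fold lower number from compound 2 to compound 4 (0.22 log units; that floor lies within the scatter), an expectation that rests on the step of an at least 1.8-fold lower number from compound 3 to compound 1 (0.27 log units; that floor lies within the scatter) and on the fact that compound 2 sits at the limit of > 50000 nM in this assay, at which 2 of the 3 values shown sit. Compound 4 is accordingly expected to give about 30000 nM, somewhere from 12000 nM to 80000 nM.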

Compound 4, half-maximal inhibitory concentration: 4430 nM
Compound 4: the middle estimate sits 6.8-fold (0.83 log units) above what was measured, outside the stated range (below it).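

On the core of compound 2, dimethylamino in place of fluoro on an aromatic carbon gives an at least 11-fold lower number from compound 2 to compound 4 (1.05 log units; beyond the scatter) in this assay. Carried from one core to the other, the change gives a lower number on both, but this does not show that the size of the step carries over: the same change on two cores in this assay, an at least 1.8-fold lower number (0.27 log units; that floor lies within the scatter) from compound 3 to compound 1 and an at least 11-fold lower number (1.05 log units; beyond the scatter) from compound 2 to compound 4; the limit leaves it open whether they differ. Neither step has a fixed size, and each can be read only as a floor, as compound 2 and compound 3 each give a limit of the assay and not a number: the limit of > 50000 nM in this assay, at which 2 of the 4 values shown sit.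

Only fluoro and dimethylamino appear at this place in the compounds shown, so it remains open how a primary amine, a methoxy group or a carboxylic acid would read there. Also open, as far as these compounds go, is whether the same change would hold on a core carrying chloro or a longer chain in place of the methyl group.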